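The source may report more compounds than this note shows. Statements on the series, on what has been measured and on what is new or still open speak of the compounds shown alone.

Three compounds have been measured in an ADME assay on J774 cells (Mus musculus) for cytotoxicity, read by MTT assay, with a stated time of 48 h, tested at 150 ug/mL; a lower number here means a stronger effect, a higher number a weaker effect of the compound at the concentration tested:

compound 1 `O=C(N/N=C/c1ccccc1)c1cnccn1`: 100%
compound 2 `O=C(N/N=C/c1ccccc1Cl)c1cnccn1`: 69%
compound 3 `O=C(N/N=C/c1ccccc1Br)c1cnccn1`: 91%

Compound 3 stands second highest of these three numbers. The two steps that lead into it are a number 9 percentage points lower from compound 1 to compound 3 (within the scatter) and a number 22 percentage points higher from compound 2 to compound 3 (beyond the scatter), so compound 3 sits within the scatter of compound 1 and apart from compound 2. The unmeasured compound 4 `COc1ccccc1/C=N/NC(=O)c1cnccn1` differs from compound 3 at one place: methoxy in place of bromo on an aromatic carbon. Among the compounds with values here, no measured step involves a methoxy group, so the only guidance is indirect. The steps on this aromatic carbon show that exchanging one group for another can shift the number beyond the scatter, as in a number 22 percentage points higher from compound 2 to compound 3 (beyond the scatter) and a number 31 percentage points lower from compound 1 to compound 2 (beyond the scatter), or leave it within the scatter, as in a number 9 percentage points lower from compound 1 to compound 3 (within the scatter). Within the data shown here, with no closer precedent, he expects compound 4 to show no step beyond the scatter, a number 3 percentage points lower from compound 3 to compound 4 (within the scatter), though with a wide allowance toward the lower end set by compound 2. His estimate for compound 4 in this assay is 88%, within the range 65% to 100%.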

Compound 4, a percentage reported as activity, at one concentration (the size of the read-out at that concentration, not a potency): 97%
Beside the measured number, compound 4's estimate is 9 percentage points below it; low and high end bracket the measured number.
By their numbers in this assay, from the lowest: compound 2; then compounds 3, 4 and 1 (each within the scatter of the next).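

In this assay, methoxy on this aromatic carbon, ortho to a large group, stays close to both neighbouring compounds, with a number 3 percentage points lower from compound 1 to compound 4 (within the scatter) and a number 6 percentage points higher from compound 3 to compound 4 (within the scatter). Methoxy has more heavy atoms than bromo and brings a hydrogen-bond acceptor, yet neither exchange moves the number beyond the scatter. The contrast with chloro now has a third member, a number 28 percentage points higher from compound 2 to compound 4 (beyond the scatter), so compound 2 stands apart from all three others at this place.

From the compounds shown here alone, whether that separation belongs to chloro alone, or would recur with an amine, a carboxylic acid or a longer alkoxy chain here or elsewhere on the ring, stays open. Nothing available accounts for the separate position of compound 2.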